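The source may hold more compounds than are shown below. What is called first, only, known or untested is meant among the compounds shown, and "the series" means these compounds.

Compound 1 `CC(C)(C)c1ccc(C(=O)N2CCC3(CC2)C(=O)N(CC(=O)N2CCCCC2CCO)CN3c2ccccc2)cc1` carries a tert-butyl aryl amide on the shared core and, on the chain amide, a 2-(2-hydroxyethyl)piperidin-1-yl group. For the measured compounds named here, in an assay on HEK293 cells for displacement of a labelled ligand from NPC1-like intracellular cholesterol transporter 1 (Homo sapiens) (on this read-out lower numbers stand for stronger inhibition and higher numbers for weaker inhibition), compound 1 gives 6100 nM, the highest of the three numbers measured so far. Compound 2 `O=C(CN1CN(c2ccccc2)C2(CCN(C(=O)c3ccc(C4CCCCC4)cc3)CC2)C1=O)NCCO` gives 2000 nM in this assay and compound 3 `CS(=O)(=O)NCCNC(=O)CN1CN(c2ccccc2)C2(CCN(C(=O)c3ccc(C4CCCCC4)cc3)CC2)C1=O` gives 2100 nM; both carry a cyclohexyl aryl amide and an open-chain amide, so their lower numbers relative to compound 1 cannot be assigned to either difference alone.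

Going by the values given here, compound 4 `CC(C)(C)c1ccc(C(=O)N2CCC3(CC2)C(=O)N(CC(=O)NCCCCO)CN3c2ccccc2)cc1` is the unmeasured analogue of compound 1. (4-hydroxybutyl)amino in place of 2-(2-hydroxyethyl)piperidin-1-yl on a carbonyl carbon The one measured step that touches the chain amide region, a 1.1-fold higher number from compound 2 to compound 3 (0.02 log units; within the scatter), exchanges only the terminal group on an open chain and leaves the number unchanged within the scatter. Among the compounds with values here, no measured pair isolates the exchange of the piperidine for an open chain, so the expected step must be a cautious one.

The change from compound 1 to compound 4 is expected to give a step of a 1.5-fold lower number from compound 1 to compound 4 (0.18 log units; within the scatter), toward but not necessarily reaching the open-chain compounds 2 and 3. Compound 4 is therefore estimated at 4000 nM in this assay, with a range from 1500 nM to 12000 nM.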

Compound 4, half-maximal inhibitory concentration: 19200 nM
Estimate against measurement, compound 4: 4.8-fold (0.68 log units) below; the measured number lies above the stated range.
By their numbers in this assay, from the lowest: compounds 2 and 3 (each within the scatter of the next); then compound 1; then compound 4.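

In this assay the exchange of 2-(2-hydroxyethyl)piperidin-1-yl for (4-hydroxybutyl)amino on a carbonyl carbon gives a 3.1-fold higher number from compound 1 to compound 4 (0.50 log units; beyond the scatter) on the tert-butyl aryl amide background, so the group at this position can move the number beyond the scatter. For the compounds shown here, the only earlier step in this region, a 1.1-fold higher number from compound 2 to compound 3 (0.02 log units; within the scatter) within the scatter, changed only the end of an open chain and gave no such sign. In this pair the open chain carries the higher number and the ring-bearing group the lower, and no measurement available here accounts for the step.

Still open, as far as these compounds go, is whether the step follows the loss of the ring, the added amide hydrogen, or the different placing of the hydroxy group, as this single pair changes all of these together. A methyl(4-hydroxybutyl)amino group, which keeps the open chain without the amide hydrogen, and a plain piperidin-1-yl group, which keeps the ring without the hydroxyethyl chain, would begin to separate them, and the same exchange on the cyclohexyl aryl amide background would show whether the step carries over.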